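Hydroxyalkylamino variants: from compound 2 to compound 3

This account rests on a few compounds, and the source may have more. Where it says the series, first, only, none or still open, it means among the compounds named here.

Measured so far:
compound 1 `Clc1ccccc1Cn1nnc2c(NC3CCCCC3)nc(-c3ccccc3)nc21` — 34 nM
compound 2 `OCCNc1nc(-c2ccccc2)nc2c1nnn2Cc1ccccc1Cl` — 116 nM

In an assay on Cerebral cortex for displacement of a labelled ligand from adenosine receptor A1 (Bos taurus) (on this read-out lower numbers stand for stronger inhibition and higher numbers for weaker inhibition), compound 2 gives 116 nM, the higher of the two numbers; the nearest measured neighbour is compound 1 with 34 nM. Among the compounds with values here, the only measured step, a 3.4-fold higher number from compound 1 to compound 2 (0.53 log units; beyond the scatter), replaces a ring with a hydroxyalkyl chain. Compound 3 `CC(O)CNc1nc(-c2ccccc2)nc2c1nnn2Cc1ccccc1Cl` carries methyl in place of hydrogen on a saturated chain carbon bound to an oxygen on a saturated carbon and a saturated chain carbon. Within the data shown here, no measured step bears directly on adding a methyl to the chain, so no change beyond the scatter is expected. The step of a 1.2-fold lower number from compound 2 to compound 3 (0.09 log units; within the scatter) is therefore expected to remain small. Compound 3 is estimated at 95 nM, with a range from 40 nM to 250 nM.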

Compound 3, inhibition constant: 32 nM
Beside the measured number, compound 3's estimate is 3.0-fold (0.47 log units) above it; the whole stated range lies above it.
By their numbers in this assay, from the lowest: compounds 3 and 1 (each within the scatter of the next); then compound 2.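

In this assay, the saturated chain carbon bound to the oxygen is sensitive to substitution: methyl in place of hydrogen there gives a 3.6-fold lower number from compound 2 to compound 3 (0.56 log units; beyond the scatter). A hydroxyalkyl chain on this nitrogen can therefore match cyclohexyl, with 2-hydroxypropyl in place of cyclohexyl giving a 1.1-fold lower number from compound 1 to compound 3 (0.03 log units; within the scatter). No evidence on the cause of the methyl step is available.

Going by these compounds, whether a longer chain or a second methyl on the same carbon would carry the trend further remains open. So does whether the hydroxyl itself matters, which a methoxy or an amine at that carbon could test.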